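Swapping an oxadiazole for an amide on the shared core

A few compounds are considered here, and "the series" means these few. Any claim that something is new, unique, unknown or untested is made for them only; others in the source may bear on it.

Of the compounds shown here, three with a shared core have been measured in an assay on microsomes from liver for inhibition of acyl-CoA desaturase 1 (Rattus norvegicus); on this read-out higher numbers stand for weaker inhibition and lower numbers for stronger inhibition. Compound 1 `FC(F)(F)c1ccc(OC2CCN(c3ccc(-n4ccnc4)nn3)CC2)cc1` gives 371 nM. Compound 2 `Oc1nnc(-c2ccc(N3CCC(Oc4ccccc4C(F)(F)F)CC3)nn2)s1` gives 6.1 nM. Compound 3 `CC(C)Cc1nnc(-c2ccc(N3CCC(Oc4ccccc4C(F)(F)F)CC3)nn2)o1` gives 15 nM, the second highest of the three numbers; its nearest neighbour is compound 2, and a 2.5-fold higher number from compound 2 to compound 3 (0.39 log units; beyond the scatter).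

Compound 4 `O=C(NCCC1CC1)c1ccc(N2CCC(Oc3ccccc3C(F)(F)F)CC2)nn1` has not yet been measured. It differs from compound 3 in one place: (2-cyclopropylethyl)carbamoyl in place of 5-isobutyl-1,3,4-oxadiazol-2-yl on an aromatic carbon. For the measured compounds named here, only one measured step touches the same position, the swap of one five-membered aromatic ring for another between compound 2 and compound 3, and it was modest. Nothing measured here shows what happens when an aromatic ring gives way to a carbamoyl group with a chain ending in a three-membered ring, so the expectation rests on a thin base.

A modest weakening is expected, a 2.7-fold higher number from compound 3 to compound 4 (0.43 log units; beyond the scatter). For compound 4 the estimate in this assay is 40 nM, with a range from 10 nM to 200 nM.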

Compound 4, half-maximal inhibitory concentration: 14 nM
Compound 4: middle estimate off by 2.9-fold (0.46 log units), on the high side, and the stated range covers the measured number.
By their numbers in this assay, from the lowest: compound 2; then compounds 4 and 3 (each within the scatter of the next); then compound 1.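

In this assay this position proves open to more than a swap of one five-membered aromatic ring for another: replacing the 5-isobutyl-1,3,4-oxadiazol-2-yl group with the (2-cyclopropylethyl)carbamoyl group, which has no aromatic ring and brings in the amide hydrogen, gives a 1.1-fold lower number from compound 3 to compound 4 (0.03 log units; within the scatter). Among the compounds that differ only here, the 5-hydroxy-1,3,4-thiadiazol-2-yl group still gives the lowest number, with a 2.3-fold higher number from compound 2 to compound 4 (0.36 log units; beyond the scatter). Nothing available explains why the carbamoyl and oxadiazole groups read alike.

Going by these compounds, what remains open is which part of the new group matters: the amide hydrogen, the carbonyl or the three-membered ring at the end of the chain. A carbamoyl group carrying a plain butyl chain, or a carboxylic acid on the same aromatic carbon, would begin to separate these parts.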